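Aryl urea exchange in a cytotoxic series: outlook for compound 4

This account rests on a few compounds, and the source may have more. Where it says the series, first, only, none or still open, it means among the compounds named here.

Three compounds of this series have been run in a functional assay on MDA-MB-231 cells (Homo sapiens) for cytotoxicity, read by MTT assay, with a stated time of 72 h; on this read-out lower numbers stand for stronger inhibition and higher numbers for weaker inhibition. Compound 1 `CN(C)CCCNc1nc(-c2ccc(NC(=O)Nc3ccccc3Cl)cc2)nc2c(Cl)c(Cl)sc12` gives 1560 nM. Compound 2 `Cc1ccc(NC(=O)Nc2ccc(-c3nc(NCCCN(C)C)c4sc(Cl)c(Cl)c4n3)cc2)cc1` gives 4980 nM. Compound 3 `CCN(CC)CCCNc1nc(-c2ccc(NC(=O)Nc3ccccc3Cl)cc2)nc2ccsc12` gives 500 nM, the lowest of the three numbers, with compound 1 nearest to it and compound 2 furthest from it, both beyond the scatter.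

Compound 1 and compound 2 differ in one place: 4-methylphenyl in place of 2-chlorophenyl on an amide-type nitrogen. That change made a 3.2-fold higher number from compound 1 to compound 2 (0.50 log units; beyond the scatter). Compound 1 and compound 3 carry different cores; the difference between the two cores is not broken down here, and only their two values are compared above.

Compound 4 `CCN(CC)CCCNc1nc(-c2ccc(NC(=O)Nc3ccc(C)cc3)cc2)nc2ccsc12` has not yet been measured in this assay. It differs from compound 3 by 4-methylphenyl in place of 2-chlorophenyl on an amide-type nitrogen. This is the same change as that from compound 1 to compound 2, and it sits on the same place, an amide-type nitrogen whose other neighbour is a carbonyl carbon; the change occurs twice among the compounds shown. Within the data shown here, only one measured instance of it exists, and that on the core of compound 1, so the expectation for compound 4 rests on carrying the step of compound 1 to compound 2 over to compound 3, with added width for the change of core. The expected step is a 3.2-fold higher number from compound 3 to compound 4 (0.51 log units; beyond the scatter) because compound 1 to compound 2 gave a 3.2-fold higher number from compound 1 to compound 2 (0.50 log units; beyond the scatter). Compound 4 is therefore estimated at 1600 nM in this assay. The estimate for compound 4 is expected to fall between 700 nM and 4000 nM.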

Compound 4, half-maximal inhibitory concentration: 1980 nM
Estimate against measurement, compound 4: 1.2-fold (0.09 log units) below, within the range that was stated.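

In this assay, 4-methylphenyl in place of 2-chlorophenyl on the amide-type nitrogen gives a 4.0-fold higher number from compound 3 to compound 4 (0.60 log units; beyond the scatter). On these two cores the change keeps both its direction and its size, so in this small set it can be treated as a step that carries from one core to the other: the same change on two cores in this assay, a 3.2-fold higher number (0.50 log units; beyond the scatter) from compound 1 to compound 2 and a 4.0-fold higher number (0.60 log units; beyond the scatter) from compound 3 to compound 4, 1.2-fold (0.09 log units) apart, within the scatter of two such steps

Among these compounds, the agreement rests on only two pairs and a single exchange of aryl groups, so it does not show that the step would hold on any further core, it gives no reason for the rise in the number, and it does not say how much of the step belongs to losing the chlorine and how much to gaining the methyl group.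

The compounds shown leave open how the step divides, which unsubstituted phenyl, 4-chlorophenyl or 2-methylphenyl on the same nitrogen could help to settle. Also open, as far as these compounds go, is whether the same step appears when the dimethylamino or diethylamino end of the side chain is replaced by a morpholine or a piperidine, or when that chain is made longer.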